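Acetoxymethyl in Place of Ethoxycarbonyl on the Shared Core

The compounds below may be only part of what the source reports. "The series", "measured", "known", "first", "only" and "open" are said of these compounds alone.

In a functional assay on the whole organism (strain CD-1) with Mus musculus as the target, with a stated time of 20 min (on this read-out lower numbers stand for an effect already at smaller amounts and higher numbers for an effect only at larger amounts of compound), compound 2 `CCOC(=O)C1CN(S(=O)(=O)c2ccc(F)cc2)CCN1C(C)=O` gives 1 mg/kg, the highest of the two numbers shown. Compound 3 `CCOC(=O)C1CN(C(C)=O)CCN1S(=O)(=O)c1ccc(F)cc1` gives 0.1 mg/kg in this assay. Compound 1 `COCC1CN(S(=O)(=O)c2ccc(F)cc2)CCN1C(C)=O` reaches only a limit of this assay, > 10 mg/kg. For the measured compounds named here, the single measured step at this ring carbon is an at least 10-fold lower number from compound 1 to compound 2 (1.00 log units; beyond the scatter), recorded against the limit (the limit of > 10 mg/kg in this assay, at which 1 of the 3 values shown sits). Compound 4 `CC(=O)OCC1CN(S(=O)(=O)c2ccc(F)cc2)CCN1C(C)=O` differs from compound 2 by acetoxymethyl in place of ethoxycarbonyl on a saturated ring carbon. As the arrival of ethoxycarbonyl in that step brought a large drop, its departure is expected to push the number back up, though the rejoined atoms make the size uncertain; the step of a 3.0-fold higher number from compound 2 to compound 4 (0.48 log units; beyond the scatter) is therefore estimated. Compound 4 is expected at about 3 mg/kg, with a range from 1 mg/kg to 10 mg/kg.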

Compound 4, minimum effective dose in the Mus musculus assay: > 10 mg/kg
Compound 4 gave a limit, no number (the forecaster's own chance of this, stated with the estimate: 30%); middle value at least 3.3-fold (0.52 log units) away from the limit.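

In the Mus musculus assay, moving the same atoms from ethoxycarbonyl to acetoxymethyl on this ring carbon gives an at least 10-fold higher number from compound 2 to compound 4 (1.00 log units; beyond the scatter), so at this position the way the atoms are joined matters, not only their number and kind. In a physicochemical assay for metabolic stability, read by LC-MS, in phosphate buffer, tested at 1 uM (on this read-out lower numbers stand for a shorter-lived compound and higher numbers for a longer-lived compound), compound 2 gives >= 4 h, a limit of the assay. In the physicochemical assay compound 4 gives >= 4 h, also a limit.

The steps in that assay and from compound 1 to compound 4 cannot be read. As far as these compounds go, how a carboxylic acid or an amine on this ring carbon would compare with ethoxycarbonyl remains open.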